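Compound 4: isopropyl in place of 1-hydroxyethyl

The source may report more compounds than this note shows. Statements on the series, on what has been measured and on what is new or still open speak of the compounds shown alone.

Values in an ADME assay on KB cells (Homo sapiens) for cytotoxicity, with a stated time of 48 h (on this read-out lower numbers stand for stronger inhibition and higher numbers for weaker inhibition), for the measured compounds follow.
compound 1 `CC1=CCC[C@](C)(CC/C(C)=C/CC2=C(O)C(=O)C=C(N[C@@H](C(=O)O)[C@@H](C)O)C2=O)[C@@H]1C` gives > 10 ug/mL (a limit)
compound 2 `C=C1[C@H](C)CCC[C@]1(C)CC/C(C)=C/CC1=C(O)C(=O)C=C(N[C@H](C(=O)O)[C@@H](C)O)C1=O` gives > 10 ug/mL (a limit)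
compound 3 `C=C1[C@H](C)CCC[C@]1(C)CC/C(C)=C/CC1=C(O)C(=O)C=C(N[C@H](CO)C(=O)O)C1=O` gives > 10 ug/mL (a limit)

Compound 1 stands at a limit and has no number. The series shows the limit of > 10 ug/mL in this assay, at which 3 of the 3 values shown sit, and nothing firmer. Compound 4 `CC1=CCC[C@](C)(CC/C(C)=C/CC2=C(O)C(=O)C=C(N[C@@H](C(=O)O)C(C)C)C2=O)[C@@H]1C` carries isopropyl in place of 1-hydroxyethyl on a saturated chain carbon bound to an amine nitrogen and a carbonyl carbon. Among the measured compounds shown here, the one measured step on this side chain is a step that the two limits leave unreadable from compound 2 to compound 3 and offers no size to carry over. No step beyond the scatter is therefore expected in this assay and no direction is favoured. The estimated step is a step that the limit leaves unreadable from compound 1 to compound 4 for now. The estimate for compound 4 is 14 ug/mL with an expected range of 6 ug/mL to 40 ug/mL in this series.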

Compound 4, half-maximal inhibitory concentration: > 10 ug/mL
Compound 4: a limit, no number; the forecaster's own chance of this, stated with the estimate: 75%; the middle value does not contradict the limit.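

No step can be read between compound 1 and compound 4 in this assay, as both stand at a limit: the limit of > 10 ug/mL in this assay, at which 4 of the 4 values shown sit.

The compounds shown leave open how isopropyl and 1-hydroxyethyl compare at this place, and what number any compound in the series would give.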